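Ester and chloro variants on a shared core

The compounds below may be only part of what the source reports. "The series", "measured", "known", "first", "only" and "open" are said of these compounds alone.

Of the compounds shown here, three have been measured in a functional assay on HCT-116 cells (Homo sapiens) for inhibition, read by fluorescence, with a stated time of 48 h; on this read-out lower numbers stand for stronger inhibition of growth and higher numbers for weaker inhibition of growth. Compound 2 `CC(=O)OCC(C)(C)COC1(c2ccc(Cl)cc2)c2ccccc2C(=O)N1Cc1ccccc1` carries an acetyl ester and gives 70000 nM. Compound 1 `CC(C)(COC(=O)[C@@H](N)c1ccccc1)COC1(c2ccc(Cl)cc2)c2ccccc2C(=O)N1Cc1ccccc1` differs from it by amino(phenyl)methyl in place of methyl on a carbonyl carbon and gives 44000 nM in this assay; the step is a 1.6-fold lower number from compound 2 to compound 1 (0.20 log units; within the scatter). Compound 3 `CC(=O)OCC(C)(C)COC1(c2ccc(Cl)cc2)c2ccccc2C(=O)N1Cc1ccc(Cl)cc1` differs from compound 2 by chloro in place of hydrogen on an aromatic carbon; in this assay compound 3 gives 70000 nM, with no change at the digits printed from compound 2 to compound 3 (within the scatter). Within the data shown here, all three numbers are high and sit close together, and none of the steps leaves the scatter, so no compound can be called more or less active than another.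

Compound 4 `CC(C)(COC(=O)[C@@H](N)c1ccccc1)COC1(c2ccc(Cl)cc2)c2ccccc2C(=O)N1Cc1ccc(Cl)cc1` has not been measured. It differs from compound 3 by amino(phenyl)methyl in place of methyl on a carbonyl carbon, the same change that carries compound 2 to compound 1; the place is the same word for word in both cases, so this is the same change applied to the core of compound 3 rather than to the core of compound 2. The two cores differ by chloro in place of hydrogen on an aromatic carbon. Among the measured compounds shown here, on the sole precedent, a 1.6-fold lower number from compound 2 to compound 1 (0.20 log units; within the scatter), the change is expected to move the number only slightly. The step from compound 3 to compound 4 in this assay is expected at a 1.6-fold lower number from compound 3 to compound 4 (0.20 log units; within the scatter), resting on the chloro step no change at the digits printed from compound 2 to compound 3 (within the scatter) having made no difference and the ester step having given only a 1.6-fold lower number from compound 2 to compound 1 (0.20 log units; within the scatter). Compound 4 is therefore estimated at 44000 nM, expected to fall within 20000 nM to 100000 nM.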

Compound 4, concentration for 50% growth inhibition: 38000 nM
Compound 4: the middle estimate sits 1.2-fold (0.06 log units) above what was measured; low and high end bracket the measured number.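

In this assay, among these compounds, amino(phenyl)methyl in place of methyl on a carbonyl carbon reads alike on the two cores, with a 1.8-fold lower number from compound 3 to compound 4 (0.27 log units; within the scatter) as the new step, and the two steps do not differ: the same change on two cores in this assay, a 1.6-fold lower number (0.20 log units; within the scatter) from compound 2 to compound 1 and a 1.8-fold lower number (0.27 log units; within the scatter) from compound 3 to compound 4, 1.2-fold (0.06 log units) apart, within the scatter of two such steps Chloro in place of hydrogen on an aromatic carbon also reads alike with either ester present, with a 1.2-fold lower number from compound 1 to compound 4 (0.06 log units; within the scatter) as the new step, and again the two steps do not differ: the same change on two cores in this assay, no change at the digits printed (within the scatter) from compound 2 to compound 3 and a 1.2-fold lower number (0.06 log units; within the scatter) from compound 1 to compound 4, 1.2-fold (0.06 log units) apart, within the scatter of two such steps Each of these steps lies within the scatter, so this shows only that neither change moved the number measurably on either core; it does not show that either change has a real effect that carries from one core to the other, and it gives no ranking among the four compounds.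

The compounds shown leave open whether an ester group other than acetyl or (amino(phenyl)methyl)carbonyl, such as a carboxylic acid on a longer chain, would move the number beyond the scatter. They also leave open whether a group other than chloro on that aromatic carbon, such as an amine or a nitrile, would do so.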